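From bromo to iodo on the shared core

The compounds below may be only part of what the source reports. "The series", "measured", "known", "first", "only" and "open" are said of these compounds alone.

Compound 1 `Nc1ccc(/C=C/C(=O)c2ccc(F)cc2)cc1` gives 40000 nM
Compound 2 `Nc1ccc(/C=C/C(=O)c2ccc(Br)cc2)cc1` gives 49000 nM
Compound 3 `Nc1ccc(/C=C/C(=O)c2ccc(I)cc2)cc1` has not yet been measured

Among the compounds with values here, in a functional assay on HeLa cells (Homo sapiens) for antiproliferative activity, with a stated time of 48 h (a higher number here means a weaker inhibitor, a lower number a stronger inhibitor), compound 2 gives 49000 nM and stands within the scatter of compound 1, the only other compound measured. Compound 3 differs from it as follows: iodo in place of bromo on an aromatic carbon. In short, it has iodo in place of bromo on an aromatic carbon. Within the data shown here, only one measured step bears on this change, bromo in place of fluoro on an aromatic carbon, which gives a 1.2-fold higher number from compound 1 to compound 2 (0.09 log units; within the scatter) and stays within the scatter. No step beyond the scatter is therefore expected in this assay. The estimated step is a 1.1-fold lower number from compound 2 to compound 3 (0.04 log units; within the scatter). Compound 3 is estimated at 45000 nM, with an expected range of 22000 nM to 85000 nM.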

Compound 3, half-maximal inhibitory concentration: 58000 nM
For compound 3 the middle estimate is 1.3-fold (0.11 log units) below the measured one; the range from low to high includes it.
By their numbers in this assay, from the lowest: compounds 1, 2 and 3 (each within the scatter of the next).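

In this assay, iodo in place of bromo on an aromatic carbon gives a 1.2-fold higher number from compound 2 to compound 3 (0.07 log units; within the scatter), and iodo in place of fluoro gives a 1.5-fold higher number from compound 1 to compound 3 (0.16 log units; within the scatter). Even the widest pair so far thus stays within the scatter, so at this place, para to a large group, fluoro, bromo and iodo cannot be told apart. No other measurement bears on this result.

From the compounds shown here alone, whether an amine, a carboxylic acid or a methoxy group at this place would move the number beyond the scatter remains open.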